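One Change Made Twice: Nitro in Place of Methoxy

A few compounds are considered here, and "the series" means these few. Any claim that something is new, unique, unknown or untested is made for them only; others in the source may bear on it.

Measured compounds:
compound 1, `COc1ccc(Cc2nnc(NC(=O)/C(C#N)=C/c3ccccc3OS(=O)(=O)c3ccc(OC)cc3)s2)cc1`: 78%
compound 2, `COc1ccc(Cc2nnc(NC(=O)/C(C#N)=C/c3ccccc3OS(=O)(=O)c3ccc([N+](=O)[O-])cc3)s2)cc1`: 70%
compound 3, `COc1ccc(S(=O)(=O)Oc2ccccc2/C=C(\C#N)C(=O)Nc2nnc(Cc3ccc(F)cc3)s2)cc1`: 76%

In a functional assay on RS4-11 cells (Homo sapiens) for inhibition, read by CCK-8 assay, with a stated time of 48 h, tested at 20 uM (on this read-out lower numbers stand for less inhibition of growth and higher numbers for more inhibition of growth at the one concentration tested), compound 1 gives 78% and compound 2 gives 70%. The change between them is nitro in place of methoxy on an aromatic carbon, and it made a number 8 percentage points lower from compound 1 to compound 2 (within the scatter). Compound 3 stands on a different core, differing from compound 1 by fluoro in place of methoxy on an aromatic carbon, with a number 2 percentage points lower from compound 1 to compound 3 (within the scatter). Compound 4, `N#C/C(=C\c1ccccc1OS(=O)(=O)c1ccc([N+](=O)[O-])cc1)C(=O)Nc1nnc(Cc2ccc(F)cc2)s1`, is not yet measured; it differs from compound 3 by nitro in place of methoxy on an aromatic carbon. The place of the change is the same word for word in both pairs, so it is the same change on the other core. For compound 4 the expected step is a number 7 percentage points lower from compound 3 to compound 4 (within the scatter), a step of about the earlier size, because a number 8 percentage points lower from compound 1 to compound 2 (within the scatter). Compound 4 is therefore estimated at 69%, with a likely range from 57% to 80%.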

Compound 4, percent growth inhibition at one concentration: 55%
For compound 4 the middle estimate is 14 percentage points above the measured one; measured number outside the range, below it.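

In this assay, nitro in place of methoxy gave a number 21 percentage points lower from compound 3 to compound 4 (beyond the scatter), and this step does not separate from the earlier one: the same change on two cores in this assay, a number 8 percentage points lower (within the scatter) from compound 1 to compound 2 and a number 21 percentage points lower (beyond the scatter) from compound 3 to compound 4, 13 percentage points apart, within the scatter of two such steps. Fluoro in place of methoxy gave a number 15 percentage points lower from compound 2 to compound 4 (beyond the scatter), and this step likewise stays within reach of its earlier counterpart: the same change on two cores in this assay, a number 2 percentage points lower (within the scatter) from compound 1 to compound 3 and a number 15 percentage points lower (beyond the scatter) from compound 2 to compound 4, 13 percentage points apart, within the scatter of two such steps. These two pairs of steps neither show that the size of either change depends on the core nor prove that it is the same on both.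

The compounds shown leave open whether an amine or a carboxylic acid in place of methoxy would carry from one core to the other in the same way. A read-out at one concentration also leaves open how these compounds compare across a range of concentrations.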